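The source may hold more compounds than are shown below. What is called first, only, known or untested is meant among the compounds shown, and "the series" means these compounds.

Measured so far: compound 1 `COc1ccc(C(=O)/C=C/c2ccc(N(C)C)cc2)c2c1C=CC(C)(C)O2` gives 1870 nM in a functional assay on HT-29 cells (Homo sapiens) for antiproliferative activity, read by MTT assay, with a stated time of 24 h; a higher number here means a weaker inhibitor, a lower number a stronger inhibitor; compound 2 `COc1ccc(C(=O)/C=C/c2ccc3ccccc3n2)c2c1C=CC(C)(C)O2` gives 3790 nM in this assay.

Compound 1 thus holds the lower of the two numbers, with compound 2 standing above it by a gap beyond the scatter. Compound 3 `COc1ccc(C(=O)/C=C/c2ccc(O)c(Br)c2)c2c1C=CC(C)(C)O2` differs from compound 1 in one place: 3-bromo-4-hydroxyphenyl in place of 4-(dimethylamino)phenyl on a double-bonded chain carbon bound to a double-bonded chain carbon. Within the data shown here, no measured pair shows this change, so its effect is open; a modest rise in the number, toward a weaker inhibitor, is expected in this assay, possibly no more than the scatter. Compound 3 is therefore estimated at 2600 nM in this assay, between 900 nM and 7500 nM, an expected step of a 1.4-fold higher number from compound 1 to compound 3 (0.14 log units; within the scatter).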

Compound 3, half-maximal inhibitory concentration: > 10000 nM
Compound 3: a limit, no number; the forecaster's own chance of this, stated with the estimate: 5%; at least 3.8-fold (0.58 log units) between middle value and limit.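

Compound 3 gives > 10000 nM in this assay, and this value is a limit of the assay, not a number. Placing 3-bromo-4-hydroxyphenyl in place of 4-(dimethylamino)phenyl on a double-bonded chain carbon bound to a double-bonded chain carbon gives an at least 5.3-fold higher number from compound 1 to compound 3 (0.72 log units; beyond the scatter), which shows that the number in this assay depends on the aryl group at this position. The full size of the step cannot be read past the limit: the limit of > 10000 nM in this assay, at which 1 of the 3 values shown sits.

Going by these compounds, the bromine and the hydroxyl enter together, so their separate contributions remain open. Also open, on these data alone, is how a phenyl carrying only one of them, or a diethylamino group, would compare with compound 1.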